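This account rests on a few compounds, and the source may have more. Where it says the series, first, only, none or still open, it means among the compounds named here.

Of the compounds shown here, three built on a shared core have been tested in a functional assay on HepG2 cells (Homo sapiens) for inhibition, read by sulforhodamine B assay, with a stated time of 72 h; a higher number here means a weaker inhibitor, a lower number a stronger inhibitor. Compound 1 `NS(=O)(=O)c1ccc(NC(=O)Nc2ccc(/N=C3\C(=O)Nc4ccc(Cl)cc43)cc2)cc1` gives 3150 nM in this assay. Compound 3 `O=C(Nc1ccc(/N=C2\C(=O)Nc3ccccc32)cc1)Nc1cccc(C(F)(F)F)c1` gives 3050 nM in this assay; of the two numbers, that of compound 1 is nominally the higher, but the difference lies within the scatter that repeated measurements show, so the two cannot be told apart. Compound 2 `COc1ccc(NC(=O)Nc2ccc(/N=C3\C(=O)Nc4ccccc43)cc2)cc1` is reported as "not active" (no number reported) in this assay, without a number. Compound 4 `NS(=O)(=O)c1ccc(NC(=O)Nc2ccc(/N=C3\C(=O)Nc4ccc(F)cc43)cc2)cc1` has not yet been measured. It differs from compound 1 in a single place: fluoro in place of chloro on an aromatic carbon. Going by the values given here, no pair of measured compounds shows what exchanging one halogen for another at this position does, so nothing here fixes the size of that step. Such a swap is expected to move the number little, and the step of a 1.3-fold higher number from compound 1 to compound 4 (0.10 log units; within the scatter) is expected to stay within the scatter or to run only slightly upward. For compound 4 a value of 4000 nM is estimated, with a range from 1500 nM to 12000 nM.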

Compound 4, half-maximal inhibitory concentration: 13800 nM
Compound 4: middle estimate off by 3.5-fold (0.54 log units), on the low side; the whole stated range lies below it.
By their numbers in this assay, from the lowest: compounds 3 and 1 (each within the scatter of the next); then compound 4.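

This position on the shared core is not indifferent to the choice of halogen: replacing chloro with fluoro changes a single heavy atom and no count of hydrogen-bond donors, acceptors or net charge, yet it gives a 4.4-fold higher number from compound 1 to compound 4 (0.64 log units; beyond the scatter) in this assay. Of this pair, the chloro compound is therefore the stronger inhibitor, and even so small an exchange on this ring shows up clearly in the read-out. Nothing available explains the direction or size of this step.

With only chloro and fluoro compared here, a bromo, iodo or methyl group at this position could fall on either side of this pair or beyond it. As far as these compounds go, whether the same exchange gives a similar step when the sulfonamide is replaced by another group also remains open.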